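The compounds below may be only part of what the source reports. "The series", "measured", "known", "first", "only" and "open" are said of these compounds alone.

Measured compounds:
- compound 1 `COc1cc(Cn2cc(COc3cccc(/C=C4/C(=O)Nc5ccccc54)c3)nn2)cc(OC)c1`: 22000 nM
- compound 2 `O=C1Nc2ccc([N+](=O)[O-])cc2/C1=C\c1cccc(OCc2cn(Cc3ccccc3)nn2)c1`: > 50000 nM

In a functional assay on HeLa cells (Homo sapiens) for inhibition, read by MTT assay, with a stated time of 48 h (a lower number here means a stronger inhibitor, a higher number a weaker inhibitor), compound 1 gives 22000 nM. Compound 2 is reported in this assay only as a limit of the assay, > 50000 nM, and with that it sits at the limit of > 50000 nM in this assay, at which 1 of the 2 values shown sits. So compound 2 stands at the edge of what the assay can report, and no number is known for it.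

Compound 3 `O=C1Nc2ccc(C(=O)c3ccccc3)cc2/C1=C\c1cccc(OCc2cn(Cc3ccccc3)nn2)c1` differs from compound 2 in one place: benzoyl in place of nitro on an aromatic carbon of the fused core, meta to a fused ring and para to a fused ring. Within the data shown here, no measured step between two compounds stands behind this change, so the direction is open. The step expected from compound 2 to compound 3 is an at least 1.6-fold lower number from compound 2 to compound 3 (0.22 log units; that floor lies within the scatter), an expectation of moderate gain that remains uncertain. Compound 3 is estimated at 30000 nM, with a range from 8000 nM to 100000 nM.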

Compound 3, half-maximal inhibitory concentration: > 50000 nM
Compound 3 ended at the assay's limit (the forecaster's own chance of this, stated with the estimate: 40%); at least 1.6-fold (0.22 log units) between middle value and limit.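

Compound 2 and compound 3 are both reported in this assay only as a limit, so no step between them can be read: the limit of > 50000 nM in this assay, at which 2 of the 3 values shown sit.

The compounds shown leave open whether benzoyl in place of nitro on an aromatic carbon changes inhibition at all, and in which direction.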